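From 1H-indazol-5-yl to quinolin-6-yl at the limit

The source may report more compounds than this note shows. Statements on the series, on what has been measured and on what is new or still open speak of the compounds shown alone.

In a functional assay on A-431 cells (Homo sapiens), read by propidium iodide staining, with a stated time of 24 h (on this read-out higher numbers stand for an effect only at larger amounts of compound and lower numbers for an effect already at smaller amounts), compound 1 `c1ccc(-c2nnc(Nc3ccc4c(c3)OCCO4)[nH]2)c(NCc2ccncc2)c1` gives > 10000 nM as a limit, not a number. Compound 2 `c1ccc(-c2nnc(Nc3ccc4c(c3)OCCO4)[nH]2)c(NCc2ccc3[nH]ncc3c2)c1` gives > 10000 nM as a limit too. For the measured compounds named here, compound 2 therefore stands at the limit of > 10000 nM in this assay, at which 2 of the 2 values shown sit, and the only measured step is a step that the two limits leave unreadable from compound 1 to compound 2 with no size to carry forward. Compound 3 `c1ccc(-c2nnc(Nc3ccc4c(c3)OCCO4)[nH]2)c(NCc2ccc3ncccc3c2)c1` has quinolin-6-yl in place of 1H-indazol-5-yl on a saturated chain carbon bound to a nitrogen on an aromatic ring, counted as quinolin-6-yl in place of 1H-indazol-5-yl on a saturated chain carbon bound to a nitrogen on an aromatic ring in full. With no readable step to lean on, no shift beyond the scatter is expected in this assay in either direction. The expected step is a number no higher from compound 2 to compound 3 (the limit leaves the size open) by this estimate. Compound 3 is expected at 10000 nM within a range of 2500 nM to 30000 nM and may again report only a limit.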

Compound 3, half-maximal effective concentration: > 10000 nM
Compound 3 was reported as a limit; the forecaster's own chance of this, stated with the estimate: 75%; the middle value lies on the limit itself.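

For the compounds shown here, compound 1, compound 2 and compound 3 all report a limit rather than a number in this assay, so no step among them can be read: the limit of > 10000 nM in this assay, at which 3 of the 3 values shown sit. The compounds shown leave open how these three groups would rank against one another.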